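Terminal groups on the ether chain of the shared core

The source may hold more compounds than are shown below. What is called first, only, known or untested is meant among the compounds shown, and "the series" means these compounds.

Measured compounds in an assay on LX2 cells for inhibition of COL1A1 promoter (Homo sapiens), read by a luciferase reporter, with a stated time of 24 h, tested at 20 uM; on this read-out higher numbers stand for a stronger effect at the one concentration tested and lower numbers for a weaker effect:
compound 1 `CN(C)c1ccc2c(=O)c(C(=O)Nc3cc(F)cc(F)c3)cn(-c3ccc(OCCCCCCC[N+]45CCN(CC4)CC5)cc3F)c2n1` gives 9.02%
compound 2 `Cc1cc(OCCCCCCC[n+]2ccccc2)ccc1-n1cc(C(=O)Nc2cc(F)cc(F)c2)c(=O)c2ccc(N(C)C)nc21` gives "not active" (no number reported), without a number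
compound 3 `CN(C)c1ccc2c(=O)c(C(=O)Nc3cc(F)cc(F)c3)cn(-c3ccc(OCCCCCCC[n+]4ccccc4)cc3F)c2n1` gives 15.4%

Compound 3 holds the higher of the two reported numbers, but the step of a number 6.4 percentage points higher from compound 1 to compound 3 (within the scatter) lies within the scatter, so compound 3 and compound 1 cannot be ordered. Compound 2 carries a methyl on the core in place of a fluorine and gives no number.

Compound 4 `CC[N+]1(CCCCCCCOc2ccc(-n3cc(C(=O)Nc4cc(F)cc(F)c4)c(=O)c4ccc(N(C)C)nc43)c(F)c2)CCCC1` differs from compound 3 by a group of 7 heavy atoms (6 carbon, 1 nitrogen; one five-membered non-aromatic ring with 1 hetero atom) in place of a group of 6 heavy atoms (5 carbon, 1 nitrogen; one six-membered aromatic ring with 1 hetero atom), on a saturated chain carbon, seven bonds along the chain from an oxygen on an aromatic ring. Among the measured compounds shown here, the one measured step that bears on it, a number 6.4 percentage points higher from compound 1 to compound 3 (within the scatter), exchanged one terminal group for another at the same place and stayed within the scatter. A further exchange of terminal group is therefore expected to give no step beyond the scatter, a number 3.4 percentage points lower from compound 3 to compound 4 (within the scatter). Compound 4 is estimated at 12%, within 0% to 26%.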

Compound 4, a percentage reported as inhibition, at one concentration (the size of the read-out at that concentration, not a potency): "not active" (no number reported)
Compound 4: no number reported, so the estimate cannot be set against anything.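

Among the compounds shown here, compound 4 has no reported number in this assay, so no step from compound 3 can be read. No other evidence bears on this result. The compounds shown leave open whether terminal groups on the ether chain separate beyond the scatter.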